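Swapping methyl(phenyl)amino for 4-methyl-2-oxopyrrolidin-1-yl: solubility outlook

The compounds below may be only part of what the source reports. "The series", "measured", "known", "first", "only" and "open" are said of these compounds alone.

Three compounds have been measured in a physicochemical assay for solubility, read by LC-MS, in phosphate buffer, with a stated time of 24 h, at pH 7.4; on this read-out lower numbers stand for lower solubility and higher numbers for higher solubility:

- Compound 1 `CNC(=O)c1ccc(-c2cnc(NCc3c(F)ccc4c3CCO4)c3cn[nH]c(=O)c23)c(C)n1` gives 19000 nM.
- Compound 2 `CN(c1ccccc1)c1cnc(NCc2c(F)ccc3c2CCO3)n2cnnc12` gives only a limit of the assay, < 2000 nM.
- Compound 3 `CNC(=O)c1ncc(-c2cnc(NCc3c(F)ccc4c3CCO4)c3cn[nH]c(=O)c23)n1C` gives 5000 nM.

As far as these compounds go, compound 2 thus stands at the limit of < 2000 nM in this assay, at which 1 of the 3 values shown sits, so its own number is unknown. The step from compound 1 to compound 3 was a 3.8-fold lower number from compound 1 to compound 3 (0.58 log units; beyond the scatter), but it changes a different group on a different core, so it does not bear on the step considered here.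

Compound 4 `C[C@H]1CC(=O)N(c2cnc(NCc3c(F)ccc4c3CCO4)n3cnnc23)C1` differs from compound 2 in one place: 4-methyl-2-oxopyrrolidin-1-yl in place of methyl(phenyl)amino on an aromatic carbon. Going by the values given here, no measured pair shares this change or this core, so nothing among the measured steps tells how far the number will move. With compound 2 known only as a limit, the step is expected to be an at least 1.5-fold higher number from compound 2 to compound 4 (0.17 log units; that floor lies within the scatter), with much uncertainty about its size. Compound 4 is therefore estimated at 3000 nM in this assay, within a range from 1000 nM to 15000 nM.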

Compound 4, solubility: 200000 nM
Estimate against measurement, compound 4: 67-fold (1.82 log units) below; measured number above the stated range.
By their numbers in this assay, from the lowest: compound 3; then compound 1; then compound 4. At a limit, below all of these: compound 2.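

In this assay, going by these compounds alone, one change on this aromatic carbon gives an at least 100-fold higher number from compound 2 to compound 4 (2.00 log units; beyond the scatter), and no earlier pair varied this group on this core, so this is the first sign of how strongly this position can move the number. That size is only a floor because compound 2 is known only as a limit of the assay: the limit of < 2000 nM in this assay, at which 1 of the 4 values shown sits. The change takes away one six-membered aromatic ring of carbon only and brings in one five-membered non-aromatic ring with a double bond outside aromatic rings, so the two compounds differ in several features at once.

Which of these features accounts for the step remains open, as a single pair cannot separate them. Comparing pyrrolidin-1-yl, which lacks the carbonyl and the methyl, or a small open-chain dimethylamino group at the same place would begin to tell them apart.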